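The source may hold more compounds than are shown below. What is called first, only, known or untested is meant among the compounds shown, and "the series" means these compounds.

Measured so far in an assay on isolated protein for displacement of a labelled ligand from prostaglandin D2 receptor 2 (Homo sapiens); on this read-out lower numbers stand for stronger inhibition and higher numbers for weaker inhibition:
- compound 1 `COc1cccc(S(=O)(=O)c2c(C)n(CC(=O)O)c3ccc(C)cc23)c1`, which gives 71 nM
- compound 2 `Cc1ccc2c(c1)c(S(=O)(=O)c1ccccc1Cl)c(C)n2CC(=O)O`, which gives 178 nM

Going by the values given here, compound 2 stands at the higher of these two numbers; its only neighbour is compound 1, and the step of a 2.5-fold higher number from compound 1 to compound 2 (0.40 log units; beyond the scatter), from the 3-methoxyphenyl to the 2-chlorophenyl on the sulfonyl sulfur, lies beyond the scatter. Compound 3 `Cc1ccc2c(c1)c(S(=O)(=O)c1cccc(Cl)c1)c(C)n2CC(=O)O` is the next member, and it differs from compound 2 only by 3-chlorophenyl in place of 2-chlorophenyl on a sulfonyl sulfur. Among the compounds with values here, no measured step matches this change exactly: the one step that is known exchanges both the group and its position at the same time, so it bears on the change only loosely. Taking the 3-substituted phenyl of compound 1 as the nearer precedent, compound 3 is expected to move back toward the lower number of compound 1, a step estimated at a 2.2-fold lower number from compound 2 to compound 3 (0.35 log units; beyond the scatter). The expected value of compound 3 in this assay is 80 nM, within a range from 25 nM to 250 nM.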

Compound 3, half-maximal inhibitory concentration: 79 nM
For compound 3 the middle estimate is 1.0-fold (0.01 log units) above the measured one; low and high end bracket the measured number.
By their numbers in this assay, from the lowest: compounds 1 and 3 (each within the scatter of the next); then compound 2.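

In this assay, 3-chlorophenyl in place of 2-chlorophenyl on the sulfonyl sulfur gives a 2.3-fold lower number from compound 2 to compound 3 (0.35 log units; beyond the scatter), so the place of the chloro matters on its own, which the earlier step could not show because it exchanged group and position together. With chloro in place of methoxy on an aromatic carbon, the step is a 1.1-fold higher number from compound 1 to compound 3 (0.05 log units; within the scatter), so this pair does not separate chloro from methoxy on this read-out, and among these three compounds the difference follows the place of the group rather than its identity. No measured evidence here explains this difference between the two chlorophenyl groups.

From the compounds shown here alone, it remains open whether the same difference holds for other groups, such as an amine or a nitrile in place of the chloro. Going by these compounds, how a plain phenyl on the sulfonyl sulfur compares with these compounds also remains open.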